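A repeated swap carried onto a second core

The source may hold more compounds than are shown below. What is called first, only, known or untested is meant among the compounds shown, and "the series" means these compounds.

compound 1 `CC(C)CN(NC(=O)OCc1ccccc1)C(=O)CN(Cc1ccccc1)NC(=O)Cc1cccc(Br)c1`: 30000 nM
compound 2 `CC(C)CN(CC(=O)NN(Cc1ccccc1)c1cnccn1)NC(=O)Cc1cccc(Br)c1`: 45000 nM
compound 3 `CC(C)CN(NC(=O)OCc1ccccc1)C(=O)CN(Cc1ccccc1)/N=C/c1cccc(B(O)O)c1`: 16200 nM

In a functional assay on L1210 cells (Mus musculus) for inhibition (a lower number here means a stronger inhibitor, a higher number a weaker inhibitor), compound 1 gives 30000 nM. Compound 3 differs from it in one place, (a group of 11 heavy atoms (7 carbon, 1 boron, 1 nitrogen, 2 oxygen; one six-membered aromatic ring of carbon only) in place of a group of 11 heavy atoms (8 carbon, 1 nitrogen, 1 oxygen, 1 bromine; one six-membered aromatic ring of carbon only), on an amine nitrogen), and the step is a 1.9-fold lower number from compound 1 to compound 3 (0.27 log units; within the scatter). Compound 2 is built on a different core; how the two cores differ is not broken down here. In this assay compound 2 gives 45000 nM, which is the highest of the three numbers. Its value and that of compound 1 lie within the scatter of each other, so no order between them can be read; the gap to compound 3 is beyond the scatter.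

Compound 4 `CC(C)CN(CC(=O)NN(Cc1ccccc1)c1cnccn1)/N=C/c1cccc(B(O)O)c1` carries the same change onto the core of compound 2: a group of 11 heavy atoms (7 carbon, 1 boron, 1 nitrogen, 2 oxygen; one six-membered aromatic ring of carbon only) in place of a group of 11 heavy atoms (8 carbon, 1 nitrogen, 1 oxygen, 1 bromine; one six-membered aromatic ring of carbon only), on an amine nitrogen. The place is the same in both pairs, an amine nitrogen whose other neighbours are two saturated chain carbons, so this is the same change, seen here twice in all, but measured only once.

Compound 4 is therefore expected to give about 24000 nM, most likely between 9000 nM and 60000 nM. For the measured compounds named here, the expected step is a 1.9-fold lower number from compound 2 to compound 4 (0.27 log units; within the scatter), set beside the measured one because a 1.9-fold lower number from compound 1 to compound 3 (0.27 log units; within the scatter) is the only information on this change, and that step is itself within the scatter. Going by the values given here, the estimate rests on the single precedent and on the value of compound 2, 45000 nM, and is accordingly uncertain.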

Compound 4, half-maximal inhibitory concentration: > 80000 nM
Compound 4 gave a limit, no number (the forecaster's own chance of this, stated with the estimate: 15%); middle value at least 3.3-fold (0.52 log units) from the limit.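

In this assay the same change on an amine nitrogen did not give the same result on the two cores, so the step seen on the core of compound 1 cannot simply be carried over to the core of compound 2: the same change on two cores in this assay, a 1.9-fold lower number (0.27 log units; within the scatter) from compound 1 to compound 3 and an at least 1.7-fold higher number (0.24 log units; that floor lies within the scatter) from compound 2 to compound 4, at least 3.2-fold (0.51 log units) apart, beyond the scatter of two such steps

Compound 4 gives > 80000 nM, which is a limit of the assay and not a number. For the compounds shown here, the new step is an at least 1.7-fold higher number from compound 2 to compound 4 (0.24 log units; that floor lies within the scatter), so its full size stays unknown, and taken alone that floor does not set compound 4 apart from compound 2; the gap between the two steps shows only that this change need not transfer between these two cores, not why it fails to, nor how the change would behave on any other core.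

The change replaces a whole group at once, so the compounds shown leave open whether the gap between the cores goes with the boron-bearing ring or with the carbon-nitrogen double bond that enters with it. They also leave open how a group carrying a carboxylic acid in place of the boron and its two oxygens would read on either core.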